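Furan-2-yl for trifluoromethyl on a camphor acylhydrazone

A few compounds are considered here, and "the series" means these few. Any claim that something is new, unique, unknown or untested is made for them only; others in the source may bear on it.

Measured compounds:
Compound 1 `CC1(C)[C@@H]2CC[C@@]1(C)/C(=N/NC(=O)C(F)(F)F)C2`: > 1070000 nM
Compound 2 `CC12C=CC3(O1)C(C(=O)N1c4ccccc4SC13)C2C(=O)N/N=C1\C[C@H]2CC[C@]1(C)C2(C)C`: 123000 nM

Two compounds have been examined in an ADME assay on MDCK cells (Canis lupus familiaris) for cytotoxicity, read by MTT assay, with a stated time of 48 h; a lower number here means that less compound is tolerated, a higher number that more compound is tolerated. Compound 1 reaches only a limit of that assay, > 1070000 nM, which is not a number but the edge of what was tested. Compound 2, a much larger structure, gives 123000 nM in this assay. Among the compounds with values here, no step between two measured compounds that differ in one place is available, so the two values show only that compound 2 sits at a number while compound 1 rests at the limit (the limit of > 1070000 nM in this assay, at which 1 of the 2 values shown sits).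

The compound not yet measured is compound 3 `CC1(C)[C@@H]2CC[C@@]1(C)/C(=N/NC(=O)c1ccco1)C2`. It differs from compound 1 in one place: furan-2-yl in place of trifluoromethyl on a carbonyl carbon. The rest of the core of compound 1 is kept unchanged.

Without a measured step to lean on, the expectation for compound 3 rests on compound 1 standing at its limit and on the modest size of the exchange. In this assay the step from compound 1 to compound 3 is expected to be an at least 1.3-fold lower number from compound 1 to compound 3 (0.12 log units; that floor lies within the scatter), a drift of no more than the scatter. Compound 3 is therefore estimated at 800000 nM, between 300000 nM and 2000000 nM, with a fair chance that only a limit is reported.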

Compound 3, half-maximal cytotoxic concentration: 1090000 nM
The estimate for compound 3 lay 1.4-fold (0.13 log units) below the measured number; measured number inside the range.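

No step can be read between compound 1 and compound 3 in this assay, because compound 1 stands at a limit and not at a number: the limit of > 1070000 nM in this assay, at which 1 of the 3 values shown sits.

The compounds shown leave open how far apart compound 1 and compound 3 truly lie, and so whether furan-2-yl in place of trifluoromethyl on a carbonyl carbon changes this read-out at all.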